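Phenyl for methyl, repeated on a second core

This account rests on a few compounds, and the source may have more. Where it says the series, first, only, none or still open, it means among the compounds named here.

In a functional assay on Huh-7 cells (Homo sapiens) for cytotoxicity, read by resazurin assay, with a stated time of 48 h (a lower number here means a stronger inhibitor, a higher number a weaker inhibitor), three compounds have been measured so far:

compound 1, `CCOc1ccc(NC(=O)c2c(N)n[nH]c2NC)cc1`: 21800 nM
compound 2, `CCOc1ccc(-n2nnc3n[nH]c(NC)c3c2=O)cc1`: 7010 nM
compound 3, `CCOc1ccc(NC(=O)c2c(N)n[nH]c2Nc2ccccc2)cc1`: 4320 nM

Compound 1 and compound 3 share one core and differ in a single place: phenyl in place of methyl on a nitrogen on an aromatic ring. This single change produced a 5.0-fold lower number from compound 1 to compound 3 (0.70 log units; beyond the scatter), a step that is clearly beyond the usual scatter of the assay.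

Compound 2 is built on a different core. The difference between the two cores is not broken down here. Set against compound 1, the number for compound 2 is lower by an amount beyond the scatter, while its number and that of compound 3 lie within the scatter of each other, so no order between those two can be read.

Compound 4, `CCOc1ccc(-n2nnc3n[nH]c(Nc4ccccc4)c3c2=O)cc1`, has not yet been measured. It differs from compound 2 as phenyl in place of methyl on a nitrogen on an aromatic ring. The surroundings of the changed position read the same as for the change from compound 1 to compound 3, so this is the same change carried onto the second core.

The expected step is a 4.4-fold lower number from compound 2 to compound 4 (0.64 log units; beyond the scatter), which may be set beside the measured 5.0-fold lower number from compound 1 to compound 3 (0.70 log units; beyond the scatter). This expectation rests on a single earlier instance of the change, measured on a different core, and is therefore held with a wide margin. Compound 4 is estimated at 1600 nM, with a range from 600 nM to 4500 nM.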

Compound 4, half-maximal inhibitory concentration: 9390 nM
Compound 4: middle estimate off by 5.9-fold (0.77 log units), on the low side, and the stated range ends below it.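

In this assay phenyl in place of methyl on a nitrogen on an aromatic ring does not repeat its earlier result on the second core: the step is a 1.3-fold higher number from compound 2 to compound 4 (0.13 log units; within the scatter) and so compound 2 and compound 4 cannot be told apart. Set side by side, the two instances of the same change disagree by more than measurement scatter alone would explain: the same change on two cores in this assay, a 5.0-fold lower number (0.70 log units; beyond the scatter) from compound 1 to compound 3 and a 1.3-fold higher number (0.13 log units; within the scatter) from compound 2 to compound 4, 6.8-fold (0.83 log units) apart, beyond the scatter of two such steps. This shows that the lower number found on the core of compound 1 did not carry over to the core of compound 2, so in this series a step measured on one core is a poor guide to the same step on the other; it does not show why the cores differ, as a single pair on each core offers no explanation and says nothing about any third core.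

The compounds shown leave open whether a group of intermediate size on that nitrogen, such as ethyl or a longer chain, would follow the same split between the two cores. They also leave open how benzyl, or a phenyl carrying a carboxylic acid or an amine, would read on either core.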